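Swapping the Fluorophenyl Arm for a Chloromethoxyphenyl

The source may hold more compounds than are shown below. What is called first, only, known or untested is meant among the compounds shown, and "the series" means these compounds.

Compound 1 `Cc1nn(-c2nc(-c3ccc(Cl)c(Cl)c3)c(SC(C)C)s2)c(C(=O)O)c1-c1cccc(F)c1` is the starting point. Among the measured compounds shown here, in a functional assay on BJAB cells (Homo sapiens) for antiproliferative activity, with a stated time of 4 days (a lower number here means that less compound is needed, a higher number that more compound is needed for the effect), compound 1 gives 900 nM, the lowest of the three numbers measured so far. Two companions share its core: compound 2 `Cc1nn(-c2nc(-c3ccc(Cl)c(Cl)c3)c(SC(C)C)s2)c(C(=O)O)c1-c1cncc(C#N)c1`, which gives 20000 nM, and compound 3 `Cc1cc(C#N)cc(-c2c(C)nn(-c3nc(-c4ccc(Cl)c(Cl)c4)c(SC(C)C)s3)c2C(=O)O)c1`, which gives 4800 nM. The step of a 22-fold higher number from compound 1 to compound 2 (1.35 log units; beyond the scatter) was large, the step of a 5.3-fold higher number from compound 1 to compound 3 (0.73 log units; beyond the scatter) was modest, and between the two weaker compounds the step of a 4.2-fold lower number from compound 2 to compound 3 (0.62 log units; beyond the scatter) was modest as well.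

Compound 4 `COc1cc(Cl)cc(-c2c(C)nn(-c3nc(-c4ccc(Cl)c(Cl)c4)c(SC(C)C)s3)c2C(=O)O)c1` has not yet been measured. It differs from compound 1 in one place: 3-chloro-5-methoxyphenyl in place of 3-fluorophenyl on an aromatic carbon. The step from compound 1 to compound 3, which also replaced the 3-fluorophenyl with a different phenyl ring, bears on this change most directly, and its modest loss is the nearest guide; the large loss from compound 1 to compound 2 involved a ring with nitrogen and is a less direct guide. A modest rise in the number is therefore expected, a 2.8-fold higher number from compound 1 to compound 4 (0.44 log units; beyond the scatter). Compound 4 is expected to give about 2500 nM in this assay, within the range 900 nM to 7000 nM.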

Compound 4, half-maximal effective concentration: 760 nM
For compound 4 the middle estimate is 3.3-fold (0.52 log units) above the measured one, outside the stated range (below it).
By their numbers in this assay, from the lowest: compounds 4 and 1 (each within the scatter of the next); then compound 3; then compound 2.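

This position accepts a bulkier arm than 3-fluorophenyl without a clear change: with a 1.2-fold lower number from compound 1 to compound 4 (0.07 log units; within the scatter), the 3-chloro-5-methoxyphenyl arm stands level with the 3-fluorophenyl arm in this assay. Compound 3 alone had suggested that a second substituent on the phenyl arm might cost activity, but a 6.3-fold lower number from compound 3 to compound 4 (0.80 log units; beyond the scatter) shows that two such arms can differ clearly, and a 26-fold lower number from compound 2 to compound 4 (1.42 log units; beyond the scatter) widens the contrast with the 5-cyanopyridin-3-yl arm, so the identity of the groups on the arm matters here. No measurement available explains these differences. The compounds shown leave open whether the chlorine, the methoxy group or the pair sets compound 4 apart from compound 3. On these data alone, how an arm carrying an amine or a longer alkoxy chain would behave in this assay also remains open.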